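Hydroxy on the benzylamine arm, second occurrence in the series

The source may hold more compounds than are shown below. What is called first, only, known or untested is meant among the compounds shown, and "the series" means these compounds.

Compound 1 `N=C(NCc1ccccc1)[C@@H]1CCC(=O)N1Cc1ccc(F)cc1` gives 31.4% in a functional assay on SH-SY5Y cells (Homo sapiens) for cytotoxicity, read by MTT assay, with stated times of 8 h, 30 min and 12 h, tested at 5 uM; on this read-out lower numbers stand for a weaker effect and higher numbers for a stronger effect at the one concentration tested. Compound 2 `N=C(NCc1ccc(O)cc1)[C@@H]1CCC(=O)N1Cc1ccc(F)cc1` gives 48.6% in this assay; the change is hydroxy in place of hydrogen on an aromatic carbon and the step is a number 17.2 percentage points higher from compound 1 to compound 2 (beyond the scatter). Compound 3 `COc1ccc(CN2C(=O)CC[C@H]2C(=N)NCc2ccccc2)cc1` gives 17.9% in this assay, the lowest of the three measured numbers; its core differs from that of compound 1 by methoxy in place of fluoro on an aromatic carbon, and the step is a number 13.5 percentage points lower from compound 1 to compound 3 (beyond the scatter). Compound 4 `COc1ccc(CN2C(=O)CC[C@H]2C(=N)NCc2ccc(O)cc2)cc1` is not yet measured in this assay. It differs from compound 3 by hydroxy in place of hydrogen on an aromatic carbon. The place is described in the same words as for the change from compound 1 to compound 2, so this is the same change, made a second time on the core of compound 3. Going by the values given here, the step to compound 4 is expected to be a number 16.1 percentage points higher from compound 3 to compound 4 (beyond the scatter), resting on the one earlier step of a number 17.2 percentage points higher from compound 1 to compound 2 (beyond the scatter) made on a different core, with nothing to show whether the core alters it. Compound 4 is estimated at 34% in this assay, between 23% and 47%.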

Compound 4, a percentage reported as activity, at one concentration (the size of the read-out at that concentration, not a potency): 26.6%
The estimate for compound 4 lay 7.4 percentage points above the measured number, and the stated range covers the measured number.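

In this assay the hydroxy change gives a number 8.7 percentage points higher from compound 3 to compound 4 (within the scatter), which alone does not establish an effect on that core, and the comparison with the earlier step shows no dependence on the core: the same change on two cores in this assay, a number 17.2 percentage points higher (beyond the scatter) from compound 1 to compound 2 and a number 8.7 percentage points higher (within the scatter) from compound 3 to compound 4, 8.5 percentage points apart, within the scatter of two such steps
The change from fluoro to methoxy gives a number 22 percentage points lower from compound 2 to compound 4 (beyond the scatter), and it too reads alike on both cores: the same change on two cores in this assay, a number 13.5 percentage points lower (beyond the scatter) from compound 1 to compound 3 and a number 22 percentage points lower (beyond the scatter) from compound 2 to compound 4, 8.5 percentage points apart, within the scatter of two such steps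
This is agreement on two cores only, and it does not show that either step would hold on any other core.

Open, on these data alone, is whether an amine or a carboxylic acid in place of the hydroxy would give a similar step. Also open, as far as these compounds go, is how a longer chain in place of the benzyl arm would read.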